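A few compounds are considered here, and "the series" means these few. Any claim that something is new, unique, unknown or untested is made for them only; others in the source may bear on it.

Compounds measured so far:
- compound 1 `COc1cc(N(Cc2ccc(C)cc2)C(=O)CSc2nc3ccccc3s2)cc(OC)c1OC`: > 80000 nM (a limit)
- compound 2 `COc1ccc(CN(C(=O)CSc2nc3ccccc3s2)c2cc(OC)c(OC)c(OC)c2)cc1[N+](=O)[O-]`: 26500 nM
- compound 3 `COc1cc(CN(C(=O)CSc2nc3ccccc3s2)c2cc(OC)c(OC)c(OC)c2)cc(OC)c1OC`: > 80000 nM (a limit)

All three were tested in a functional assay on PC-3 cells (Homo sapiens) for antiproliferative activity, read by MTT assay, with a stated time of 48 h; on this read-out lower numbers stand for stronger inhibition and higher numbers for weaker inhibition. Compound 3 has no numerical value, only a limit of the assay: > 80000 nM. The small set is dominated by the limit of > 80000 nM in this assay, at which 2 of the 3 values shown sit.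

Compound 4 `COc1ccc(CN(C(=O)CSc2nc3ccccc3s2)c2cc(OC)c(OC)c(OC)c2)cc1Br` differs from compound 3 in one place, on a saturated chain carbon bound to an amide-type nitrogen: 3-bromo-4-methoxyphenyl in place of 3,4,5-trimethoxyphenyl on a saturated chain carbon bound to an amide-type nitrogen. Its 3-bromo-4-methoxyphenyl group shares a methoxy group with the 4-methoxy-3-nitrophenyl of compound 2, so the most relevant measured change is an at least 3.0-fold higher number from compound 2 to compound 3 (0.47 log units; beyond the scatter). Among the measured compounds shown here, the mirror of that comparison is an at least 3.0-fold lower number from compound 1 to compound 2 (0.47 log units; beyond the scatter), which also points to 4-methoxy-3-nitrophenyl as the one group that gave a measurable number. By contrast, a step that the two limits leave unreadable from compound 1 to compound 3 adds nothing. Going by these compounds, compound 2 at 26500 nM is therefore the only numerical anchor, and bromine in place of nitro is untested. In this assay, a lower number than the limit of compound 3 is expected, at least a modest step, though compound 4 could still reach the limit. The expected change is an at least 2.6-fold lower number from compound 3 to compound 4 (0.42 log units; beyond the scatter). For compound 4 the estimated value is 30000 nM, with an expected range from 10000 nM to 80000 nM.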

Compound 4, half-maximal inhibitory concentration: 16000 nM
Estimate against measurement, compound 4: 1.9-fold (0.27 log units) above, within the range that was stated.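

In this assay, the change on a saturated chain carbon bound to an amide-type nitrogen gives an at least 5.0-fold lower number from compound 3 to compound 4 (0.69 log units; beyond the scatter), and the same kind of change gives an at least 5.0-fold lower number from compound 1 to compound 4 (0.69 log units; beyond the scatter), so 3-bromo-4-methoxyphenyl is a second group at this position that yields a number, and a measurable value is not tied to the nitro group. For compound 1 and compound 3 there is only a limit of the assay, not a number, so both steps are minimum sizes: the limit of > 80000 nM in this assay, at which 2 of the 4 values shown sit. Bromo in place of nitro on an aromatic carbon gives a 1.7-fold lower number from compound 2 to compound 4 (0.22 log units; within the scatter), so the two groups cannot be put in any order here.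

The compounds shown leave open whether another group on that aromatic carbon, such as chloro, a nitrile or an amine, would give a lower number, and whether the methoxy group shared by compound 2 and compound 4 is needed for a measurable value. They also leave open what an unsubstituted phenyl would do in place of the 3,4,5-trimethoxyphenyl that all four compounds keep on the amide-type nitrogen.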